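A selenium-bearing group in place of methylsulfanyl

This account rests on a few compounds, and the source may have more. Where it says the series, first, only, none or still open, it means among the compounds named here.

Of the compounds shown here, three built on one shared core have been tested in a functional assay on HT-29 cells (Homo sapiens) for cytotoxicity, read by MTT assay, with a stated time of 72 h; a lower number here means that less compound is tolerated, a higher number that more compound is tolerated. Compound 1 `CS/C(=N\C(=O)c1sccc1Cl)NC(=O)c1sccc1Cl` reaches only a limit, > 100000 nM, not a number. Compound 2 `CS/C(=N\C(=O)c1ccno1)NC(=O)c1ccno1` likewise gives only a limit, > 100000 nM. Compound 3 `CS/C(=N\C(=O)c1cc2ccccc2s1)NC(=O)c1cc2ccccc2s1` gives 88200 nM. Compound 2 thus stands at the limit of > 100000 nM in this assay, at which 2 of the 3 values shown sit, so where it truly lies is not known. Compound 4 `O=C(/N=C(/NC(=O)c1ccno1)[Se]Cc1ccccc1)c1ccno1` differs from compound 2 by a group of 8 heavy atoms (7 carbon, 1 selenium; one six-membered aromatic ring of carbon only) in place of a group of 2 heavy atoms (1 carbon, 1 sulfur; no ring), on a carbon with a double bond to nitrogen. Among the measured compounds shown here, no measured pair shows this kind of change, so the size of the step in this assay cannot be read from the data. The expected step is an at least 1.4-fold lower number from compound 2 to compound 4 (0.15 log units; that floor lies within the scatter), no larger than the usual scatter. Compound 4 is therefore expected to give about 70000 nM, within a range from 20000 nM to 300000 nM.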

Compound 4, concentration lethal to 50% of the cells: > 100000 nM
Compound 4: only a limit was reported (the forecaster's own chance of this, stated with the estimate: 55%); middle value at least 1.4-fold (0.15 log units) from the limit.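

No step from compound 2 to compound 4 can be read, because both give only a limit, not a number: the limit of > 100000 nM in this assay, at which 3 of the 4 values shown sit.

Going by these compounds, whether putting the selenium-bearing group in place of methylsulfanyl changes the value at all stays open.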